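The source may report more compounds than this note shows. Statements on the series, on what has been measured and on what is new or still open speak of the compounds shown alone.

For the measured compounds named here, in a functional assay on MCF7 cells (Homo sapiens) for cytotoxicity, read by MTT assay (a lower number here means a stronger inhibitor, a higher number a weaker inhibitor), compound 2 (`C[C@H]1[C@H](O)C[C@@H](CCO)N[C@H]1c1ccccc1`) gives 39800 nM, the higher of the two numbers so far, while compound 1 (`COC(=O)C[C@@H]1C[C@@H](O)[C@H](C)[C@H](c2ccccc2)N1`) gives 5400 nM. Next is compound 3 (`C[C@H]1[C@H](O)C[C@@H](CC(=O)O)N[C@H]1c1ccccc1`), with carboxy in place of hydroxymethyl on a saturated chain carbon bound to a saturated ring carbon. Going by the values given here, the only measured step bearing on this change, a 7.4-fold higher number from compound 1 to compound 2 (0.87 log units; beyond the scatter), is modest but involves no carboxy, so no step beyond the scatter is expected in this assay. The expected step is a 1.3-fold lower number from compound 2 to compound 3 (0.12 log units; within the scatter). For compound 3 the estimate is 30000 nM, with an estimated range of 10000 nM to 90000 nM.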

Compound 3, half-maximal inhibitory concentration: 23100 nM
The estimate for compound 3 lay 1.3-fold (0.11 log units) above the measured number; low and high end bracket the measured number.
By their numbers in this assay, from the lowest: compound 1; then compounds 3 and 2 (each within the scatter of the next).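

With carboxy in place of hydroxymethyl on this saturated chain carbon, this assay shows a 1.7-fold lower number from compound 2 to compound 3 (0.24 log units; within the scatter) and so does not separate these two groups. Removing the methyl from the ester oxygen brings a 4.3-fold higher number from compound 1 to compound 3 (0.63 log units; beyond the scatter) and places compound 3 with compound 2, leaving compound 1 alone at the low end of the series. Nothing available explains this difference.

The compounds shown leave open whether the lower number of compound 1 is particular to methoxycarbonyl. An amide, an amine or a longer chain ending in an ester at this position could test that.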